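The source may hold more compounds than are shown below. What is called first, only, known or untested is meant among the compounds shown, and "the series" means these compounds.

In a functional assay on WI-38 VA13 cells (Homo sapiens) for cytotoxicity (a lower number here means that less compound is needed, a higher number that more compound is needed for the effect), compound 1 `Cc1ccc(F)cc1S(=O)(=O)Nc1ccc2nc(NC(=O)C3CCCCC3)sc2c1` gives 0.7 ug/mL. Compound 2 `CC(=O)Nc1nc2ccc(NC(=O)c3c(Cl)cccc3Cl)cc2s1` gives 0.6 ug/mL in this assay; its number differs from that of compound 1 by less than the usual scatter, so the two compounds cannot be told apart on these data. Compound 3 `O=C(Nc1nc2ccc(NC(=O)c3c(Cl)cccc3Cl)cc2s1)OCc1ccccc1` has not yet been measured. It differs from compound 2 in one place: benzyloxy in place of methyl on a carbonyl carbon. For the measured compounds named here, no measured pair shows this change, so its effect is unknown from the data here. The step of a 1.7-fold higher number from compound 2 to compound 3 (0.22 log units; within the scatter) is expected to stay small, at or just beyond the scatter. For compound 3 the estimate in this assay is 1 ug/mL, with a range from 0.3 ug/mL to 3 ug/mL.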

Compound 3, half-maximal effective concentration: 0.018 ug/mL
The estimate for compound 3 lay 56-fold (1.74 log units) above the measured number; the whole stated range lies above it.
By their numbers in this assay, from the lowest: compound 3; then compounds 2 and 1 (each within the scatter of the next).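

In this assay, this carbonyl carbon on the amide-type nitrogen proves sensitive to what it carries: benzyloxy in place of methyl gives a 33-fold lower number from compound 2 to compound 3 (1.52 log units; beyond the scatter). The earlier compounds shown here differ in more than one place, so they could not reveal this. No measurement here accounts for the size of this step. On these data alone, it remains open whether the aromatic ring or the added oxygen of benzyloxy matters, which methoxy or phenyl at this carbon could help separate. How a longer chain such as butoxy or an amine would behave there is also unknown.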